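A few compounds are considered here, and "the series" means these few. Any claim that something is new, unique, unknown or untested is made for them only; others in the source may bear on it.

Within the data shown here, in a functional assay on NCI-H460 cells (Homo sapiens) for cytotoxicity, read by MTT assay, with a stated time of 72 h (a higher number here means a weaker inhibitor, a lower number a stronger inhibitor), the three measured members stand as follows: compound 1 `COc1cc2c(Oc3ccc(NC(=O)c4nn(-c5ccc(Br)cc5)c(=O)c5ccccc45)cc3F)ccnc2cc1OCCCN1CCCC1` gives 180 nM; compound 2 `COc1cc2c(Oc3ccc(NC(=O)c4nn(-c5ccccc5Br)c(=O)c5ccccc45)cc3F)ccnc2cc1OCCCN1CCCC1` gives 320 nM; compound 3 `COc1cc2c(Oc3ccc(NC(=O)c4nn(-c5ccc(Br)cc5)c(=O)c5ccccc45)cc3F)ccnc2cc1OCCCN1CCC(C)CC1` gives 350 nM.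

Compound 2 differs from compound 1 by 2-bromophenyl in place of 4-bromophenyl on an aromatic nitrogen, and the step was a 1.8-fold higher number from compound 1 to compound 2 (0.25 log units; within the scatter). Compound 3 differs from compound 1 by 4-methylpiperidin-1-yl in place of pyrrolidin-1-yl on a saturated chain carbon, three bonds along the chain from an oxygen on an aromatic ring, and that step was a 1.9-fold higher number from compound 1 to compound 3 (0.29 log units; within the scatter). Among the measured compounds shown here, compound 2 and compound 3 have no step computed between them; their two values lie close together.

Compound 4 `COc1cc2c(Oc3ccc(NC(=O)c4nn(-c5ccccc5Br)c(=O)c5ccccc45)cc3F)ccnc2cc1OCCCN1CCC(C)CC1` is not yet measured. It differs from compound 3 by 2-bromophenyl in place of 4-bromophenyl on an aromatic nitrogen. This is the same change as that from compound 1 to compound 2, made here on the core of compound 3 rather than the core of compound 1; the surroundings of the place are described in the same words in both cases. For the measured compounds named here, from compound 3 to compound 4 a step of about a 1.8-fold higher number from compound 3 to compound 4 (0.25 log units; within the scatter) is expected in this assay, resting on the single earlier instance, which gave a 1.8-fold higher number from compound 1 to compound 2 (0.25 log units; within the scatter). For compound 4 the estimate is 620 nM, with a range from 300 nM to 1300 nM.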

Compound 4, half-maximal inhibitory concentration: 390 nM
The estimate for compound 4 lay 1.6-fold (0.20 log units) above the measured number; low and high end bracket the measured number.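

In this assay, 2-bromophenyl in place of 4-bromophenyl on the core of compound 3 gave a 1.1-fold higher number from compound 3 to compound 4 (0.05 log units; within the scatter), which agrees with the earlier instance of the same change: the same change on two cores in this assay, a 1.8-fold higher number (0.25 log units; within the scatter) from compound 1 to compound 2 and a 1.1-fold higher number (0.05 log units; within the scatter) from compound 3 to compound 4, 1.6-fold (0.20 log units) apart, within the scatter of two such steps. 4-methylpiperidin-1-yl in place of pyrrolidin-1-yl, now with 2-bromophenyl on the aromatic nitrogen, gave a 1.2-fold higher number from compound 2 to compound 4 (0.09 log units; within the scatter), and this too agrees with its earlier instance: the same change on two cores in this assay, a 1.9-fold higher number (0.29 log units; within the scatter) from compound 1 to compound 3 and a 1.2-fold higher number (0.09 log units; within the scatter) from compound 2 to compound 4, 1.6-fold (0.20 log units) apart, within the scatter of two such steps. Among these compounds, both changes therefore carry from one core to the other without a step beyond the scatter, but with all four steps inside the scatter this shows only that neither change has a measurable effect here, not that a real effect transfers or that the two changes add.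

As far as these compounds go, it remains open whether a phenyl without bromine or a 4-methoxyphenyl on the aromatic nitrogen would give a step beyond the scatter. The same question stands for morpholin-4-yl or dimethylamino in place of the saturated ring amine, and for a longer chain leading to it.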